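Cyclopropyl to cyclohexyl on a slowly cleared compound

The compounds below may be only part of what the source reports. "The series", "measured", "known", "first", "only" and "open" are said of these compounds alone.

In an in vitro ADME assay on microsomes from liver (Homo sapiens) for metabolic stability (on this read-out higher numbers stand for fast clearance and lower numbers for slow clearance), compound 3 (`Clc1ccc(-c2n[nH]cc2-c2ccnc(NC3CC3)n2)cc1`) stands highest at 0.096 mL/min/kg and lies above compound 2 (`CC(C)Nc1nccc(-c2cn[nH]c2)n1`) at 0.021 mL/min/kg and compound 1 (`CS(=O)(=O)N[C@H]1CC[C@H](c2n[nH]cc2-c2ccnc(NC3CCCC3)n2)CC1`) at 0.011 mL/min/kg and both of these gaps go beyond the usual scatter. Compound 4 (`Clc1ccc(-c2n[nH]cc2-c2ccnc(NC3CCCCC3)n2)cc1`) has cyclohexyl in place of cyclopropyl on a nitrogen on an aromatic ring. Going by the values given here, no two measured compounds differ in just one place, so the data offer no direct guide to the size of this change and the expectation is a cautious one. The estimated step of a 1.6-fold higher number from compound 3 to compound 4 (0.19 log units; within the scatter) is small and upward and may well stay within the scatter. In this assay compound 4 is expected at 0.15 mL/min/kg (estimated range 0.05 mL/min/kg to 0.45 mL/min/kg).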

Compound 4, clearance: 0.156 mL/min/kg
The estimate for compound 4 lay 1.0-fold (0.02 log units) below the measured number, and the stated range covers the measured number.
By their numbers in this assay, from the lowest: compounds 1 and 2 (each within the scatter of the next); then compounds 3 and 4 (each within the scatter of the next).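

In this assay, going by these compounds alone, this is the first pair that differs in one place only, and cyclohexyl in place of cyclopropyl on the nitrogen gives a 1.6-fold higher number from compound 3 to compound 4 (0.21 log units; within the scatter). So at this position, a much larger carbon ring leaves the read-out within the usual scatter, at least with the rest of compound 3 held fixed. Nothing available explains this result.

Still open, on these data alone, is whether a ring carrying an oxygen, such as tetrahydropyranyl, or a longer chain such as n-butyl, would stay as close. The same swap might also read differently on the core of compound 1.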